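Shortening the amino-acid side chain from compound 3 to compound 4

The source may hold more compounds than are shown below. What is called first, only, known or untested is meant among the compounds shown, and "the series" means these compounds.

Compound 1, `COC(=O)[C@H](CC(C)C)NC(=O)c1ccc(/C=C2\SC(=O)N(CC(=O)NOCc3ccccc3)C2=O)cc1`, in a functional assay on RAW264.7 cells (Mus musculus) for inhibition, read by microscopy and resazurin assay, with a stated time of 72 h (a higher number here means a weaker inhibitor, a lower number a stronger inhibitor), gives > 128000 nM, which is a limit of the assay and not a number.
Compound 2, `C=CCONC(=O)CN1C(=O)S/C(=C\c2cccc(C(=O)N[C@@H](CC(C)C)C(=O)OC)c2)C1=O`, gives > 128000 nM, again a limit.
Compound 3, `COC(=O)[C@H](CC(C)C)NC(=O)c1cccc(/C=C2\SC(=O)N(CC(=O)NOCc3ccccc3)C2=O)c1`, gives > 128000 nM, also a limit.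

Compound 3 therefore stands only at a limit, as do the other two values, because of the limit of > 128000 nM in this assay, at which 3 of the 3 values shown sit. Going by the values given here, the one step between measured compounds, a step that the two limits leave unreadable from compound 2 to compound 3, cannot be read. Compound 4, `COC(=O)[C@@H](NC(=O)c1cccc(/C=C2\SC(=O)N(CC(=O)NOCc3ccccc3)C2=O)c1)C(C)C`, differs from compound 3 by isopropyl in place of isobutyl on a saturated chain carbon bound to an amide-type nitrogen and a carbonyl carbon. Among the compounds with values here, no measured step touches this side chain, so the data give no direction. Compound 4 is expected to sit at or beyond the limit as well, with an estimated 200000 nM and a range from 60000 nM to 1000000 nM. The expected step that the limit leaves unreadable from compound 3 to compound 4 is thus estimated to be unreadable.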

Compound 4, half-maximal inhibitory concentration: > 128000 nM
Compound 4 was reported as a limit; the forecaster's own chance of this, stated with the estimate: 85%; the middle value is on the limit's open side.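

The step from compound 3 to compound 4, isopropyl in place of isobutyl, cannot be read, because both compounds stand only at a limit: the limit of > 128000 nM in this assay, at which 4 of the 4 values shown sit.

As far as these compounds go, whether this side chain affects inhibition at all in this assay remains open.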